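The compounds below may be only part of what the source reports. "The series", "measured", "known", "first", "only" and "open" are said of these compounds alone.

Measured compounds in an ADME assay on MDCK cells (Canis lupus familiaris) for cytotoxicity, read by microscopy, with a stated time of 48 h; on this read-out lower numbers stand for higher toxicity in this test and higher numbers for lower toxicity in this test:
Compound 1, `C[C@H]1[C@H](NCc2cc(Br)cs2)C[C@H]2C[C@@H]1C2(C)C`, gives 6250 nM.
Compound 2, `C[C@H]1[C@H](NCc2cc(-c3ccsc3)cs2)C[C@H]2C[C@@H]1C2(C)C`, gives 25000 nM.
Compound 3, `C[C@H]1[C@H](NCc2sccc2-c2ccsc2)C[C@H]2C[C@@H]1C2(C)C`, gives 12500 nM.

Compound 4, `C[C@H]1[C@H](NCc2sccc2Br)C[C@H]2C[C@@H]1C2(C)C`, has not yet been measured in this assay. It differs from compound 3 by bromo in place of thiophen-3-yl on an aromatic carbon. The same kind of change leads from compound 2 to compound 1, (bromo in place of thiophen-3-yl on an aromatic carbon); there the place lies two ring bonds from the ring atom that bears a large group, whereas in compound 4 it lies next to the ring atom that bears a large group. The difference between the cores of compound 2 and compound 3 is not broken down here. The earlier change produced a 4.0-fold lower number from compound 2 to compound 1 (0.60 log units; beyond the scatter). For compound 4 a step of comparable size is expected, a 4.0-fold lower number from compound 3 to compound 4 (0.61 log units; beyond the scatter), resting on that one precedent because a 4.0-fold lower number from compound 2 to compound 1 (0.60 log units; beyond the scatter) lies beyond the scatter. Compound 4 is accordingly estimated at 3100 nM, between 1500 nM and 7000 nM.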

Compound 4, minimum cytotoxic concentration: 50000 nM
Compound 4: the middle estimate sits 16-fold (1.21 log units) below what was measured; the measured number lies above the stated range.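

In this assay, the step of a 4.0-fold higher number from compound 3 to compound 4 (0.60 log units; beyond the scatter) is the new result for bromo in place of thiophen-3-yl. Set beside the earlier case, the same exchange does not carry over from one core to the other, and its direction reverses: the same change on two cores in this assay, a 4.0-fold lower number (0.60 log units; beyond the scatter) from compound 2 to compound 1 and a 4.0-fold higher number (0.60 log units; beyond the scatter) from compound 3 to compound 4, 16-fold (1.20 log units) apart, beyond the scatter of two such steps The two bromo compounds also differ, with an 8.0-fold higher number from compound 1 to compound 4 (0.90 log units; beyond the scatter) when 3-bromothiophen-2-yl replaces 4-bromothiophen-2-yl, yet this rests on one pair per core and does not show why the outcome depends on the place of the change. The compounds shown leave open whether chloro or methyl in the same place would follow compound 4 or compound 1. They also leave open how phenyl would compare with thiophen-3-yl on either core.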